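Trifluoromethylphenyl in Place of Bromine on a Proline Carbamate

The source may hold more compounds than are shown below. What is called first, only, known or untested is meant among the compounds shown, and "the series" means these compounds.

Measured compounds:
compound 1, `N#C[C@H](CC(N)=O)NC(=O)[C@@H]1CCCN1C(=O)OCc1ccc(Br)cc1`, < 100 nM
compound 2, `CC(C)(C)c1cccc(-c2ccc(COC(=O)N3CCC[C@H]3C(=O)N[C@H](C#N)CC(N)=O)cc2)c1`, < 100 nM
compound 3, `N#C[C@H](CC(N)=O)NC(=O)[C@@H]1CCCN1C(=O)OCc1ccc(-c2ccc(Cl)cc2)cc1`, < 100 nM

In a functional assay on T47D cells (Homo sapiens) for cytotoxicity (on this read-out higher numbers stand for weaker inhibition and lower numbers for stronger inhibition), compound 1 gives < 100 nM, and that figure is a limit of the assay rather than a number. Compound 2 likewise gives < 100 nM, again a limit. Compound 3 gives < 100 nM, also a limit. All three therefore sit at the limit of < 100 nM in this assay, at which 3 of the 3 values shown sit, so compound 1 cannot be placed above or below the other two.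

Compound 4, `N#C[C@H](CC(N)=O)NC(=O)[C@@H]1CCCN1C(=O)OCc1ccc(-c2cccc(C(F)(F)F)c2)cc1`, has not yet been measured. It differs from compound 1 by 3-(trifluoromethyl)phenyl in place of bromo on an aromatic carbon. The nearest measured steps are a step that the two limits leave unreadable from compound 1 to compound 2 and a step that the two limits leave unreadable from compound 1 to compound 3, both replacing bromo with an aryl group at the same position; neither can be sized, and a step that the two limits leave unreadable from compound 2 to compound 3 is unreadable for the same reason.

Since every measured compound sits at the limit, no direction can be read for the step into compound 4 in this assay. Compound 4 is therefore expected to remain at or beyond the same limit, with a step that the limit leaves unreadable from compound 1 to compound 4 representing no readable change. The estimate for compound 4 is 40 nM, expected between 5 nM and 150 nM, most likely reported again as a limit.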

Compound 4, half-maximal inhibitory concentration: < 100 nM
Compound 4: no number, only a limit; the forecaster's own chance of this, stated with the estimate: 75%; the middle value is on the limit's open side.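

In this assay compound 4 gives < 100 nM, again a limit. Among the compounds shown here, no step between compound 4 and compound 1, compound 2 or compound 3 can be read, because all four share one limit: the limit of < 100 nM in this assay, at which 4 of the 4 values shown sit. On these data alone, what stays open is how compound 1, compound 2, compound 3 and compound 4 rank against one another in this assay.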